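The source may report more compounds than this note shows. Statements on the series, on what has been measured and on what is new or still open speak of the compounds shown alone.

Measured compounds:
compound 1 `Cc1ccc(S(=O)(=O)c2cnc3ccc(F)cc3c2N2CCC(C)CC2)cc1`, 91%
compound 2 `Cc1ccc(S(=O)(=O)c2cnc3ccc(Cl)cc3c2N2CCC(C)CC2)cc1`, 95%
compound 3 `CC1CCN(c2c(S(=O)(=O)c3ccc(Cl)cc3)cnc3cc(Cl)ccc23)CC1`, 91%

In an assay on isolated protein for displacement of a labelled ligand from metabotropic glutamate receptor 5 (Homo sapiens), with a stated time of 60 min, tested at 1 uM (on this read-out higher numbers stand for more inhibition at the one concentration tested (going by the name of the read-out) and lower numbers for less inhibition), compound 2 gives the highest of the three numbers, though both neighbours lie within the scatter: compound 1 stands at 91% and compound 3 at 91%, so no order among them can be claimed. Within the data shown here, the one single-point step, a number 4 percentage points higher from compound 1 to compound 2 (within the scatter), is itself within the scatter.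

Compound 4 `Cc1ccc(S(=O)(=O)c2cnc3ccc(Cl)cc3c2N2CCC(C)CC2)cc1C` differs from compound 2 by methyl in place of hydrogen on an aromatic carbon. No measured step bears on this change; the only step shown concerns a different position, and compound 3 differs from compound 2 in more than one place. In this assay compound 4 is therefore expected to show a step of a number 2 percentage points lower from compound 2 to compound 4 (within the scatter), none beyond the scatter. Compound 4 is estimated at 93%, between 80% and 99%.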

Compound 4, a percentage reported as inhibition, at one concentration (the size of the read-out at that concentration, not a potency): 84%
For compound 4 the middle estimate is 9 percentage points above the measured one; the range from low to high includes it.
By their numbers in this assay, from the lowest: compounds 4, 1, 3 and 2 (each within the scatter of the next, the first and the last beyond it).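

Going from 4-methylphenyl to 3,4-dimethylphenyl gives a number 11 percentage points lower from compound 2 to compound 4 (beyond the scatter) in this assay, the first step between compounds differing in one place here to lie beyond the scatter. This aromatic carbon, ortho to a methyl group, therefore takes an added methyl with a modest loss, although compound 4 still gives 84% at the one concentration tested. Nothing available gives a reason for this loss. Going by these compounds, whether a methoxy or an amine on this carbon would give a similar loss stays open, as does whether a longer chain such as ethyl would give a larger one.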